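From urea to oxalamide at the side-chain amine

A few compounds are considered here, and "the series" means these few. Any claim that something is new, unique, unknown or untested is made for them only; others in the source may bear on it.

Compound 3 `COc1ccc(/C(=C(/CCNC(=O)N2CCCC2)c2ccccc2)c2ccccc2)cc1` stands at the weak end of what has been measured. In a functional assay on MCF7 cells (Homo sapiens) for cytotoxicity, read by MTT assay, with a stated time of 72 h (a lower number here means a stronger inhibitor, a higher number a weaker inhibitor), compound 3 reaches only a limit, > 50000 nM. The parent amine, compound 1 `COc1ccc(/C(=C(/CCN)c2ccccc2)c2ccccc2)cc1`, gives 16900 nM in this assay. Compound 2 `CCOC(=O)C(=O)NCC/C(=C(\c1ccccc1)c1ccc(OC)cc1)c1ccccc1` likewise reaches only a limit in this assay, > 50000 nM. Accordingly an at least 2.9-fold higher number from compound 1 to compound 2 (0.47 log units; beyond the scatter) and an at least 2.9-fold higher number from compound 1 to compound 3 (0.47 log units; beyond the scatter), whereas a step that the two limits leave unreadable from compound 2 to compound 3. Compound 4 `COc1ccc(/C(=C(/CCNC(=O)C(=O)N2CCCC2)c2ccccc2)c2ccccc2)cc1` differs from compound 3 by (pyrrolidin-1-yl)carbonyl in place of pyrrolidin-1-yl on a carbonyl carbon. For the measured compounds named here, the one measured step between two acyl groups is unreadable, and both acylated compounds sit at the limit of > 50000 nM in this assay, at which 2 of the 3 values shown sit. The step that the limit leaves unreadable from compound 3 to compound 4 is therefore expected to keep the number at that limit. Compound 4 is estimated at 60000 nM, within 30000 nM to 150000 nM.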

Compound 4, half-maximal inhibitory concentration: > 50000 nM
Compound 4: no number, only a limit; the forecaster's own chance of this, stated with the estimate: 85%; the middle value does not contradict the limit.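

Compound 4 shows that the oxalamide bearing pyrrolidin-1-yl fares no differently from the other acylated compounds in this assay, so a pyrrolidine amide on the second carbonyl gives no readable gain over the urea or the ethyl ester. Set against the parent amine, there is an at least 2.9-fold higher number from compound 1 to compound 4 (0.47 log units; beyond the scatter). The steps among the three acylated compounds cannot be read, and all three now sit at one limit: the limit of > 50000 nM in this assay, at which 3 of the 4 values shown sit.

Only the free amine, compound 1, gives a number here. On these data alone, whether a dimethylamino group, a carboxylic acid or a longer chain on this nitrogen would move the value stays open.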